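Benzyl substituent and cytotoxicity in a triazole ether series

A few compounds are considered here, and "the series" means these few. Any claim that something is new, unique, unknown or untested is made for them only; others in the source may bear on it.

compound 1 `Cc1cccc(Cn2cc(COc3ccc4c(=O)ccoc4c3)nn2)c1`: > 100000 nM
compound 2 `N#Cc1ccc(Cn2cc(COc3ccc4c(=O)ccoc4c3)nn2)cc1`: > 100000 nM
compound 3 `O=c1ccoc2cc(OCc3cn(Cc4ccc([N+](=O)[O-])cc4)nn3)ccc12`: 25700 nM

Among the compounds with values here, in a functional assay on HeLa cells (Homo sapiens) for cytotoxicity, read by MTT assay, with a stated time of 48 h (a lower number here means a stronger inhibitor, a higher number a weaker inhibitor), compound 3 holds the only actual number of the three, standing at 25700 nM. For compound 1 the entry is a limit of this assay (the limit of > 100000 nM in this assay, at which 2 of the 3 values shown sit). For compound 2 the entry is likewise a limit. Compound 4, `O=c1ccoc2cc(OCc3cn(Cc4cccc(F)c4)nn3)ccc12`, differs from compound 3 in one place: 3-fluorophenyl in place of 4-nitrophenyl on a saturated chain carbon bound to an aromatic nitrogen. Within the data shown here, two measured steps bear on this change: an at least 3.8-fold lower number from compound 1 to compound 3 (0.59 log units; beyond the scatter) and an at least 3.8-fold lower number from compound 2 to compound 3 (0.59 log units; beyond the scatter). In both, the compound lacking the nitro group sits at the limit. For compound 4, which also lacks the nitro group, a weaker result is therefore expected, a 3.9-fold higher number from compound 3 to compound 4 (0.59 log units; beyond the scatter), quite possibly reported only as a limit. Compound 4 is estimated at 100000 nM, within 30000 nM to 300000 nM.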

Compound 4, half-maximal inhibitory concentration: 7550 nM
Compound 4: middle estimate off by 13-fold (1.12 log units), on the high side; measured number outside the range, below it.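

In this assay, a nitro group is not needed on the ring at this place, as the change to 3-fluorophenyl gives a 3.4-fold lower number from compound 3 to compound 4 (0.53 log units; beyond the scatter). A single exchange on the ring can also lift a compound clear of the assay limit, with an at least 13-fold lower number from compound 1 to compound 4 (1.12 log units; beyond the scatter) for fluoro in place of methyl, and an at least 13-fold lower number from compound 2 to compound 4 (1.12 log units; beyond the scatter) for 3-fluorophenyl in place of 4-cyanophenyl. No measurement shown accounts for this order. Going by these compounds, whether the gain belongs to fluoro or to its ring position stays open. Also open, on these data alone, is how 4-fluorophenyl, an amine or carboxylic acid on the ring, or a longer chain at this place would read.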